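This account rests on a few compounds, and the source may have more. Where it says the series, first, only, none or still open, it means among the compounds named here.

Measured so far: compound 1 `O=C(/C=C/c1ccc2c(c1)B(O)OC2)c1ccc(F)cc1` gives 7600 nM in a toxicity assay on WI-38 cells (Homo sapiens) for cytotoxicity, read by MTT assay, with a stated time of 48 h; on this read-out higher numbers stand for weaker inhibition and lower numbers for stronger inhibition. Compound 2 `O=C(/C=C/c1ccc2c(c1)B(O)OC2)c1ccc(OCc2ccccc2)cc1` reaches only a limit of this assay, > 100000 nM. Compound 3 `O=C(/C=C/c1ccc2c(c1)B(O)OC2)c1ccc([N+](=O)[O-])cc1` gives 39300 nM in this assay.

Compound 1 holds the lowest of the two numbers; its nearest neighbour is compound 3, a 5.2-fold higher number from compound 1 to compound 3 (0.71 log units; beyond the scatter). Compound 4 `O=C(/C=C/c1ccc2c(c1)B(O)OC2)c1ccccc1O` has not been measured; it differs from compound 1 by 2-hydroxyphenyl in place of 4-fluorophenyl on a carbonyl carbon. Both measured steps start from the same fluoro group: an at least 13-fold higher number from compound 1 to compound 2 (1.11 log units; beyond the scatter) and a 5.2-fold higher number from compound 1 to compound 3 (0.71 log units; beyond the scatter), and both raised the number. Neither step brings in a 2-hydroxyphenyl group, so they guide the direction only loosely. A modest rise is expected: a 2.0-fold higher number from compound 1 to compound 4 (0.30 log units; within the scatter). Compound 4 is therefore estimated at 15000 nM, within 5000 nM to 60000 nM.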

Compound 4, half-maximal inhibitory concentration: > 100000 nM
Compound 4 was reported as a limit; the forecaster's own chance of this, stated with the estimate: 10%; middle value at least 6.6-fold (0.82 log units) away from the limit.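

Putting 2-hydroxyphenyl in place of 4-fluorophenyl on the carbonyl carbon gives an at least 13-fold higher number from compound 1 to compound 4 (1.11 log units; beyond the scatter) in this assay. So a large rise at this position does not need a larger group: the heavy-atom count stays unchanged here, whereas the benzyloxy group of compound 2 adds to it. Compound 4 gives a limit, not a number, and it cannot be ranked against compound 2, whose value is the same limit: the limit of > 100000 nM in this assay, at which 2 of the 4 values shown sit.

Going by these compounds, whether the rise belongs to the hydroxyl group or to its place on the ring stays open. A 4-hydroxyphenyl or 2-methoxyphenyl group on the carbonyl carbon would bear on that question.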